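The compounds below may be only part of what the source reports. "The series", "measured", "known", "first", "only" and "open" are said of these compounds alone.

Measured so far:
compound 1 `CCc1cccc(NC(=O)N[C@@H](C)c2ccccc2)c1` – 100%
compound 2 `C[C@H](NC(=O)Nc1cccc(Br)c1)c1ccccc1` – 100%

In an ADME assay on the whole organism with Oryza sativa as the target, tested at 0.1 uM (a higher number here means a weaker effect of the compound at the concentration tested, a lower number a stronger effect), compound 1 gives 100%, and in the same assay compound 2 gives 100%. Compound 2 therefore stands level with compound 1 on the numbers shown; the only measured step, no change at the digits printed from compound 1 to compound 2 (within the scatter), lies within the scatter, so nothing here separates the two compounds.

Compound 3 `C[C@H](NC(=O)Nc1cccc(I)c1)c1ccccc1` differs from compound 2 in one place: iodo in place of bromo on an aromatic carbon. Within the data shown here, the one measured step that bears on this change is the exchange of one group for another at the same aromatic carbon, no change at the digits printed from compound 1 to compound 2 (within the scatter), and it brought no change beyond the scatter. On that basis compound 3 is expected to stay at the same level as compound 2, an expected step of no change at the digits printed from compound 2 to compound 3 (within the scatter) in this assay. The estimate for compound 3 in this assay is 100%, with a range from 90% to 100%.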

Compound 3, a percentage reported as activity, at one concentration (the size of the read-out at that concentration, not a potency): 98%
Beside the measured number, compound 3's estimate is 2 percentage points above it; low and high end bracket the measured number.
By their numbers in this assay, from the lowest: compounds 3, 1 and 2 (each within the scatter of the next).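

In this assay, iodo in place of bromo on this aromatic carbon gives a number 2 percentage points lower from compound 2 to compound 3 (within the scatter), and iodo in place of ethyl gives a number 2 percentage points lower from compound 1 to compound 3 (within the scatter). Ethyl, bromo and iodo, each meta to a large group, thus all stand within the scatter of one another, extending to a third group what the single earlier step showed for only one pair. Nothing further is available to explain this result.

The compounds shown leave open whether a group of another kind on this aromatic carbon, such as an amine or a carboxylic acid, would move the number beyond the scatter. No compound shown stands apart from the others, so they also leave open whether this assay at this concentration can register any change at this place.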